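Removing a fluoro from compound 1 on a shared core

The source may hold more compounds than are shown below. What is called first, only, known or untested is meant among the compounds shown, and "the series" means these compounds.

In an ADME assay on A549 cells (Homo sapiens) for inhibition, read by MTT assay (on this read-out higher numbers stand for weaker inhibition of growth and lower numbers for stronger inhibition of growth), compound 1, `Cc1nc(-c2ccc(F)cc2)oc1-c1csc(Cc2cccc(Cl)c2)n1`, gives a limit of the assay rather than a number, > 250 ug/mL. Compound 2, `Cc1nc(-c2ccccc2)oc1-c1csc(Cc2ccc(Cl)cc2)n1`, likewise gives only a limit in this assay, > 250 ug/mL. Compound 3, `Cc1nc(-c2ccc(F)cc2)oc1-c1csc(Cc2ccccc2)n1`, also reaches only a limit in this assay, > 250 ug/mL. Compound 1 therefore stands where every measured compound stands, because of the limit of > 250 ug/mL in this assay, at which 3 of the 3 values shown sit. Going by the values given here, the single step between measured compounds that differ in one place, a step that the two limits leave unreadable from compound 1 to compound 3, cannot be sized, since both of its ends are limits.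

Compound 4, `Cc1nc(-c2ccccc2)oc1-c1csc(Cc2cccc(Cl)c2)n1`, differs from compound 1 in one place: hydrogen in place of fluoro on an aromatic carbon. Among the compounds with values here, no measured step follows this exact change. Within the data shown here, the only step available, a step that the two limits leave unreadable from compound 1 to compound 3, concerns a different group and offers no readable size, so the data give no reason to expect a step in this assay beyond the scatter in either direction. Compound 4 is expected to sit at the same limit as compound 1, with an estimated value near 300 ug/mL, ranging from 120 ug/mL to 800 ug/mL. The step from compound 1 to compound 4 is expected to be a step that the limit leaves unreadable from compound 1 to compound 4, which in practice means another limit is the most likely outcome.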

Compound 4, concentration for 50% growth inhibition: > 250 ug/mL
Compound 4: only a limit was reported; the forecaster's own chance of this, stated with the estimate: 85%; the middle value is on the limit's open side.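

Neither the step from compound 1 to compound 4 nor the step from compound 2 to compound 4 can be read, because each joins two limits in this assay: the limit of > 250 ug/mL in this assay, at which 4 of the 4 values shown sit.

The compounds shown leave open how strongly any of them inhibits growth, and whether hydrogen in place of fluoro, or 3-chlorophenyl in place of 4-chlorophenyl, changes that at all.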